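Removing an ethyl group from a quinoline-oxadiazole series

A few compounds are considered here, and "the series" means these few. Any claim that something is new, unique, unknown or untested is made for them only; others in the source may bear on it.

Measured compounds and values:
Compound 1, `CCOC(=O)c1cnc2ccc(-c3ccccc3)cc2c1`, gives only the assay limit > 7400 nM in a functional assay on RD cells (Homo sapiens) for inhibition, read by luminescence and ATP content, with a stated time of 72 h; on this read-out lower numbers stand for higher toxicity in this test and higher numbers for lower toxicity in this test.
Compound 2, `Cc1nc(-c2cnc3ccc(-c4ccc(N)cc4)cc3c2)no1`, gives only the assay limit > 2500 nM in this assay.
Compound 3, `CCc1ccc(-c2ccc3ncc(-c4noc(C)n4)cc3c2)cc1`, gives only the assay limit > 7400 nM in this assay.

Among the measured compounds shown here, every value so far is a limit rather than a number, so no compound can be ranked against another. Compound 3 stands at a limit, as do the two other values; one value sits at the limit of > 2500 nM in this assay, at which 1 of the 3 values shown sits, and two sit at the limit of > 7400 nM in this assay, at which 2 of the 3 values shown sit. For the measured compounds named here, the one step between compounds differing in a single place, a step that the two limits leave unreadable from compound 2 to compound 3, cannot be read because both ends are limits.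

Compound 4, `Cc1nc(-c2cnc3ccc(-c4ccccc4)cc3c2)no1`, differs from compound 3 by hydrogen in place of ethyl on an aromatic carbon. Going by the values given here, no measured step bears on this change in a readable way. The expectation in this assay is therefore that compound 4 again shows no toxicity beyond the range tested, with an estimated step that the limit leaves unreadable from compound 3 to compound 4 that stays within the scatter. Compound 4 is estimated at 10000 nM, between 3000 nM and 40000 nM.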

Compound 4, half-maximal cytotoxic concentration: > 2500 nM
Compound 4: only a limit was reported (the forecaster's own chance of this, stated with the estimate: 80%); the middle value lies beyond the limit too.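

Compound 4 also gives a limit rather than a number, so its steps from compound 1, compound 2 and compound 3 cannot be read. The compounds shown leave open at what concentration any of them turns toxic in this assay, and whether removing the ethyl group changes that.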